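Swapping the aryl group on the triazole-linked thiazolidinedione

The source may hold more compounds than are shown below. What is called first, only, known or untested is meant among the compounds shown, and "the series" means these compounds.

Of the compounds shown here, three sharing one core have been tested in a functional assay on the whole organism (strain Wistar) with Rattus norvegicus as the target, with a stated time of 15 days, at a dose of 30 mg/kg by the oral route; on this read-out higher numbers stand for a stronger effect at the one dose given and lower numbers for a weaker effect. Compound 1 `Cc1nc(COc2ccc(/C=C3\SC(=O)NC3=O)cc2)cs1` gives 26.4%. Compound 2 `O=C1NC(=O)/C(=C/c2ccc(OCCSc3nnc(Cc4ccccc4)[nH]3)cc2)S1` gives 38.3%. Compound 3 `Cc1ccc(-c2nnc(SCCOc3ccc(/C=C4\SC(=O)NC4=O)cc3)[nH]2)cc1` gives 40.3%. Of the three numbers, that of compound 3 is the largest, but compound 2 comes within the usual scatter of it, so these two cannot be told apart; only compound 1 lies clearly lower. Going by the values given here, the one measured step at the same position, a number 2 percentage points higher from compound 2 to compound 3 (within the scatter), shows that changing the group on the triazole ring from benzyl to 4-methylphenyl made no difference beyond the scatter.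

Compound 4 `O=C1NC(=O)/C(=C/c2ccc(OCCSc3nnc(-c4ccccc4[N+](=O)[O-])[nH]3)cc2)S1` has not yet been measured. It differs from compound 3 in one place: 2-nitrophenyl in place of 4-methylphenyl on an aromatic carbon. Among the compounds with values here, no measured pair shows a nitro group entering at this position, so the only guide is the step from compound 2 to compound 3, which was small. On that basis the step of a number 5.3 percentage points lower from compound 3 to compound 4 (within the scatter) is expected to stay within the scatter, with perhaps a slight lowering. Compound 4 is therefore estimated to give 35% in this assay, within a range from 20% to 50%.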

Compound 4, a percentage reported as activity, at one dose (the size of the read-out at that dose, not a potency): 38.6%
Compound 4: the middle estimate sits 3.6 percentage points below what was measured; measured number inside the range.
By their numbers in this assay, from the lowest: compound 1; then compounds 2, 4 and 3 (each within the scatter of the next).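

Placing 2-nitrophenyl on this aromatic carbon of the five-membered ring gives a number 1.7 percentage points lower from compound 3 to compound 4 (within the scatter) in this assay, and set against the benzyl group it gives a number 0.3 percentage points higher from compound 2 to compound 4 (within the scatter). Until now, this position had been compared only between benzyl and 4-methylphenyl, whereas the entering group has 9 heavy atoms in place of 7, includes nitrogen and oxygen, and carries 2 hydrogen-bond acceptors in place of 0, yet compounds 2, 3 and 4 still cannot be told apart on this read-out. No measurement at hand explains why such different groups give values this close.

On these data alone, all three groups tested here contain a six-membered aromatic ring of carbon only, so it remains open whether the read-out would also stay level with a group lacking that ring, such as an amine, a carboxylic acid or a plain butyl chain, on the same carbon. Each number also comes from a single dose, so compounds that look alike here could still differ at other doses.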